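From hydroxy to propoxy on compound 3

The source may hold more compounds than are shown below. What is called first, only, known or untested is meant among the compounds shown, and "the series" means these compounds.

In a functional assay on RAW264.7 cells (Mus musculus) for inhibition, read by Griess assay, with stated times of 1 h and 24 h (a lower number here means a stronger inhibitor, a higher number a weaker inhibitor), compound 3 `COc1cc(OC)c2c(c1)C(C(O)c1ccc(O)cc1)OC2=O` reads > 10000 nM, which is a limit and not a number. Compound 1 `O=C1OC(Cc2nc(-c3ccccc3)no2)c2ccccc21` reads > 10000 nM, also a limit. Compound 2 `O=C1OC(Cc2nc(-c3ccc(-c4ccccc4)cc3)no2)c2ccccc21` reads > 10000 nM, again a limit. All three therefore stand at the limit of > 10000 nM in this assay, at which 3 of the 3 values shown sit.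

Compound 4 `CCCOc1ccc(C(O)C2OC(=O)c3c(OC)cc(OC)cc32)cc1` carries propyl in place of hydrogen on an oxygen on an aromatic ring, hydroxy to propoxy.

For the measured compounds named here, the only measured step is a step that the two limits leave unreadable from compound 1 to compound 2. It concerns phenyl in place of hydrogen on an aromatic carbon and offers no size to carry over. In this assay the expected change is a number no higher from compound 3 to compound 4 (the limit leaves the size open), with no direction clearly favoured. For compound 4 the estimated value is 10000 nM, with an expected range of 3000 nM to 30000 nM.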

Compound 4, half-maximal inhibitory concentration: 9260 nM
Beside the measured number, compound 4's estimate is 1.1-fold (0.03 log units) above it; the measured number falls inside the stated range.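

On the oxygen on an aromatic ring, propyl in place of hydrogen gives in this assay an at least 1.0-fold lower number from compound 3 to compound 4 (0.03 log units; that floor lies within the scatter). On these data alone, compound 3 is only a limit, so the real size of this step stays open, and it may be larger than that floor. Compound 4 is the only compound shown with a number rather than a limit, and the others stay at the limit: the limit of > 10000 nM in this assay, at which 3 of the 4 values shown sit.

Open, as far as these compounds go, is whether methyl or ethyl on this oxygen already gives a number. Also open, from the compounds shown here alone, is whether a longer chain such as hexyl, or a propyl chain ending in an amine, gives a lower one.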